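Ester Oxygen Swapped for an Amide Nitrogen

This account rests on a few compounds, and the source may have more. Where it says the series, first, only, none or still open, it means among the compounds named here.

Of the compounds shown here, three built on one shared core have been tested in an assay on isolated protein for inhibition of protein kinase C zeta type (Homo sapiens), with stated times of 1 h and 2.5 min, tested at 30 uM; a higher number here means more inhibition at the concentration tested (going by the name of the read-out), a lower number less inhibition. Compound 1 `COCC(C)OC(=O)c1c(-c2ccc(OC)c(OC)c2)csc1N` gives 49%, compound 2 `COc1ccc(-c2csc(N)c2C(=O)OCc2ccccc2C)cc1OC` gives 64%, and compound 3 `COc1ccc(-c2csc(N)c2C(=O)OCc2ccc(F)cc2)cc1OC` gives 2%. Compound 1 therefore stands second highest of the three: compound 2 sits a number 15 percentage points higher from compound 1 to compound 2 (beyond the scatter), whereas compound 3 sits a number 47 percentage points lower from compound 1 to compound 3 (beyond the scatter). Between the two benzyl esters the swing is a number 62 percentage points lower from compound 2 to compound 3 (beyond the scatter), so within this small set the group carried by the carbonyl carbon clearly governs the inhibition percentage.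

Compound 4 `CCNC(=O)c1c(-c2ccc(OC)c(OC)c2)csc1N` has not yet been measured. It differs from compound 1 by ethylamino in place of 1-(methoxymethyl)ethoxy on a carbonyl carbon. For the measured compounds named here, no measured step exchanges an oxygen-linked group for a nitrogen-linked one, so the three known steps bear on this change only indirectly: they show that alterations at the carbonyl carbon shift the read-out by large amounts in both directions, and they give no way to tell which way an amide will move. A step of real size is therefore possible, but its sign is open. Compound 4 is estimated to give 35%, within 5% to 65%. That estimate corresponds to a step of a number 14 percentage points lower from compound 1 to compound 4 (beyond the scatter).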

Compound 4, a percentage reported as inhibition, at one concentration (the size of the read-out at that concentration, not a potency): 50%
The estimate for compound 4 lay 15 percentage points below the measured number; the range from low to high includes it.
By their numbers in this assay, from the lowest: compound 3; then compounds 1 and 4 (each within the scatter of the next); then compound 2.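

Swapping 1-(methoxymethyl)ethoxy for ethylamino on the carbonyl carbon replaces a group of 6 heavy atoms and no hydrogen-bond donor with one of 3 heavy atoms and 1 hydrogen-bond donor, yet this assay shows a number 1 percentage points higher from compound 1 to compound 4 (within the scatter), so this exchange of an ester for an amide leaves the read-out unmoved in this pair. Set against the two benzyl esters, the same ethylamino group gives a number 48 percentage points higher from compound 3 to compound 4 (beyond the scatter) and a number 14 percentage points lower from compound 2 to compound 4 (beyond the scatter), which shows that an ester oxygen is not required on this carbonyl carbon for inhibition at this level and places the amide within the range the esters span. Nothing at hand explains why the read-out holds across this change.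

A single small amide leaves open whether a longer chain such as butylamino, or a dimethylamino group, which has no amide hydrogen, would keep this level of inhibition. From the compounds shown here alone, it also remains open whether the wide gap between the 2-methylbenzyl and 4-fluorobenzyl esters would return in the matching amides, such as one carrying 2-methylbenzylamino on the carbonyl carbon.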